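Swapping Methylsulfonyl for Ethyl on the Amine Nitrogen

The source may report more compounds than this note shows. Statements on the series, on what has been measured and on what is new or still open speak of the compounds shown alone.

Measured so far, in an assay on isolated protein for inhibition of ubiquitin carboxyl-terminal hydrolase 7 (Homo sapiens), with stated times of 30 min and 2 h; on this read-out lower numbers stand for stronger inhibition and higher numbers for weaker inhibition:
- compound 1, `Cn1nc2c(=O)n(CC3(O)CCN(Cc4ccc(-c5ccco5)cc4Cl)CC3)cnc2c1-c1ccc(CNC=O)cc1`, gives 20.9 nM
- compound 2, `Cn1nc2c(=O)n(CC3(O)CCN(Cc4ccc(-c5ccco5)cc4Cl)CC3)cnc2c1-c1ccc(CNS(C)(=O)=O)cc1`, gives 65.3 nM

Within the data shown here, compound 2 stands at the higher of the two numbers: the only step known is a 3.1-fold higher number from compound 1 to compound 2 (0.49 log units; beyond the scatter), and that step separates it from compound 1.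

Compound 3 is `CCNCc1ccc(-c2c3ncn(CC4(O)CCN(Cc5ccc(-c6ccco6)cc5Cl)CC4)c(=O)c3nn2C)cc1`. It differs from compound 2 in one place: ethyl in place of methylsulfonyl on an amine nitrogen. The group that leaves carries two hydrogen-bond acceptors and two double bonds outside aromatic rings; the ethyl that enters carries none of either.

Among the measured compounds shown here, only one measured step exists, and it swaps one acceptor-bearing group for another on this same amine nitrogen. It shows that the group on this nitrogen does move the number, but it says nothing about replacing it with a plain carbon chain. For the measured compounds named here, with no step that truly bears on the change, the direction is open, and the expectation is a step of no more than modest size, expressed as a 1.3-fold lower number from compound 2 to compound 3 (0.12 log units; within the scatter). Compound 3 is therefore estimated at 50 nM, with a range from 12 nM to 200 nM.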

Compound 3, half-maximal inhibitory concentration: 15.2 nM
Beside the measured number, compound 3's estimate is 3.3-fold (0.52 log units) above it; the measured number falls inside the stated range.
By their numbers in this assay, from the lowest: compounds 3 and 1 (each within the scatter of the next); then compound 2.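

The amine nitrogen does not need a group carrying hydrogen-bond acceptors to reach the low end of the numbers seen so far: in this assay ethyl, which has none, gives a 4.3-fold lower number from compound 2 to compound 3 (0.63 log units; beyond the scatter), a step beyond the usual scatter. Set against formyl, ethyl gives a 1.4-fold lower number from compound 1 to compound 3 (0.14 log units; within the scatter), which lies within the scatter, so these two groups cannot be told apart on this read-out, and among the three compounds only methylsulfonyl stands clearly apart, with the higher number. Nothing available explains why the number moves with these groups.

As far as these compounds go, three groups are too few to show a trend at this nitrogen, so it remains open whether a longer chain such as propyl, a small ring such as cyclopropyl, or a bare amine with only hydrogen in place of the ethyl would stay level with ethyl and formyl. From the compounds shown here alone, it is equally open whether acetyl would sit with formyl or move toward methylsulfonyl, which would help show whether the change in the number follows the kind of group or something else about it.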